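Cyclic amides on the ketoamide carbonyl of the chlorophenyl series

The source may report more compounds than this note shows. Statements on the series, on what has been measured and on what is new or still open speak of the compounds shown alone.

In an assay on HEK-293T cells for inhibition of phospholipase A and acyltransferase 2 (Homo sapiens), with stated times of 30 min and 20 min (on this read-out higher numbers stand for weaker inhibition and lower numbers for stronger inhibition), compound 1 `CCNC(=O)C(=O)CCc1ccc(Cl)cc1` gives 2510 nM.
In this assay compound 2 `O=C(CCc1ccc(Cl)cc1)C(=O)N1CCCCC1` gives > 10000 nM, a limit of the assay.
In this assay compound 3 `O=C(CCc1ccc(Cl)cc1)C(=O)N1CCOCC1` gives > 10000 nM, again a limit.

Compound 3 therefore stands at the limit of > 10000 nM in this assay, at which 2 of the 3 values shown sit; no number is known for it. The next compound, compound 4 `O=C(CCc1ccc(Cl)cc1)C(=O)N1CCCC1`, carries pyrrolidin-1-yl in place of morpholin-4-yl on a carbonyl carbon. For the measured compounds named here, the steps that bear on it are an at least 3.9-fold higher number from compound 1 to compound 2 (0.60 log units; beyond the scatter) and an at least 3.9-fold higher number from compound 1 to compound 3 (0.60 log units; beyond the scatter), each an at least modest weakening on replacing the open ethylamino amide by a cyclic tertiary amide; a step that the two limits leave unreadable from compound 2 to compound 3 between the two cyclic amides cannot be read. A third cyclic tertiary amide is expected to behave like those two, so no step beyond the scatter is expected from compound 3 to compound 4, a step that the limit leaves unreadable from compound 3 to compound 4. Compound 4 is estimated at 12000 nM, in the range 4000 nM to 40000 nM, most likely reported as a limit.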

Compound 4, half-maximal inhibitory concentration: > 10000 nM
Compound 4: a limit, no number; the forecaster's own chance of this, stated with the estimate: 65%; the middle value is on the limit's open side.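

The weakening is not confined to six-membered cyclic amides: the five-membered pyrrolidin-1-yl amide also shows it, with an at least 3.9-fold higher number from compound 1 to compound 4 (0.60 log units; beyond the scatter). The steps among compound 2, compound 3 and compound 4 cannot be read, so these three rings cannot be ranked in this assay. The cyclic amides now all sit at one assay limit: the limit of > 10000 nM in this assay, at which 3 of the 4 values shown sit.

Still open, from the compounds shown here alone, is whether an open tertiary amide, with methyl and ethyl on the amide nitrogen, behaves like the rings. Also open, going by these compounds, is whether a longer chain on the secondary amide of compound 1 changes inhibition.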